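Dimethylamino to 4-methylpiperidin-1-yl on compound 2

A few compounds are considered here, and "the series" means these few. Any claim that something is new, unique, unknown or untested is made for them only; others in the source may bear on it.

In a functional assay on MDA-MB-231 cells (Homo sapiens) for cytotoxicity, read by MTT assay, with a stated time of 72 h (on this read-out lower numbers stand for stronger inhibition and higher numbers for weaker inhibition), compound 1 (`CN(C)Cc1ccc2nc(NC(=O)N/N=C/c3cn(Cc4ccccc4Cl)c4ccccc34)sc2c1`) gives 1180 nM, compound 2 (`CN(C)Cc1ccc2nc(NC(=O)N/N=C/c3cn(Cc4ccc(C(C)(C)C)cc4)c4ccccc34)sc2c1`) gives 2230 nM and compound 3 (`Cc1ccc(Cn2cc(/C=N/NC(=O)Nc3nc4ccc(CN(C)C)cc4s3)c3ccccc32)cc1`) gives 1220 nM. Compound 2 stands within the scatter of both others, as a 1.9-fold higher number from compound 1 to compound 2 (0.28 log units; within the scatter) and a 1.8-fold lower number from compound 2 to compound 3 (0.26 log units; within the scatter) show. Compound 4 (`CC1CCN(Cc2ccc3nc(NC(=O)N/N=C/c4cn(Cc5ccc(C(C)(C)C)cc5)c5ccccc45)sc3c2)CC1`) has 4-methylpiperidin-1-yl in place of dimethylamino on a saturated chain carbon bound to an aromatic carbon. Within the data shown here, no measured step touches that place. These steps, along with a 1.0-fold higher number from compound 1 to compound 3 (0.01 log units; within the scatter), change another part of the structure, so they are only a weak guide. No change beyond the scatter is expected in this assay, and the expected step is a 1.1-fold lower number from compound 2 to compound 4 (0.05 log units; within the scatter). For compound 4 the estimate is 2000 nM, with an expected range of 700 nM to 5500 nM.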

Compound 4, half-maximal inhibitory concentration: 3880 nM
Beside the measured number, compound 4's estimate is 1.9-fold (0.29 log units) below it, within the range that was stated.
By their numbers in this assay, from the lowest: compounds 1, 3, 2 and 4 (each within the scatter of the next, the first and the last beyond it).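

In this assay, the first change measured on the saturated chain carbon bound to an aromatic carbon, 4-methylpiperidin-1-yl in place of dimethylamino, gives a 1.7-fold higher number from compound 2 to compound 4 (0.24 log units; within the scatter) and so stays within the scatter. This position on the compound with the 4-(tert-butyl)phenyl group therefore accepts a six-membered non-aromatic ring in place of the open dimethylamino group with no change beyond the scatter. No available evidence bears on what lies behind this result.

As far as these compounds go, whether the same exchange holds with 2-chlorophenyl or 4-methylphenyl in place of 4-(tert-butyl)phenyl remains open. So does the outcome with morpholin-4-yl or a carboxylic acid at this place.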